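Removing the para chloro from compound 1

This account rests on a few compounds, and the source may have more. Where it says the series, first, only, none or still open, it means among the compounds named here.

The shared core of compound 1 `COc1cc(/C=C/C(=O)c2sc(Nc3ccc(Cl)cc3)nc2C)cc(OC)c1OC` carries an anilino substituent bearing chloro and a trimethoxystyryl ketone. In a functional assay on BGC-823 cells (Homo sapiens) for cytotoxicity, read by MTT assay (a lower number here means a stronger inhibitor, a higher number a weaker inhibitor), compound 1 gives only a limit of > 25000 nM, not a number. Among the two values shown, one sits at that limit (the limit of > 25000 nM in this assay, at which 1 of the 2 values shown sits). A second measured compound, compound 2 `Cc1nc(Nc2ccccc2)sc1C(=O)/C=C/c1ccccc1`, carries an unsubstituted anilino and an unsubstituted styryl ketone; in this assay compound 2 gives 19500 nM.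

Compound 3 `COc1cc(/C=C/C(=O)c2sc(Nc3ccccc3)nc2C)cc(OC)c1OC` is the unmeasured analog of compound 1, differing in one place: hydrogen in place of chloro on an aromatic carbon. Among the compounds with values here, no step between measured compounds follows this change. The expected step in this assay from compound 1 to compound 3 is a number no higher from compound 1 to compound 3 (the limit leaves the size open), which is not beyond the scatter, and it is expected that this assay may again report only a limit for compound 3. The estimate for compound 3 is 25000 nM, with a range from 8000 nM to 80000 nM, and rests on the weak value of compound 2, which gives 19500 nM with the same unsubstituted anilino.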

Compound 3, half-maximal inhibitory concentration: > 25000 nM
Compound 3: a limit, no number; the forecaster's own chance of this, stated with the estimate: 55%; the middle value sits exactly at the limit.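

In this assay, within the data shown here, compound 3 gives > 25000 nM, a limit and not a number, so no step from compound 1 to compound 3 can be read. Both compounds stand at the same limit: the limit of > 25000 nM in this assay, at which 2 of the 3 values shown sit.

The compounds shown leave open whether going from 4-chlorophenyl to phenyl changes the result in this assay at all.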